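Cysteamine amides: dropping the ester on the thiol chain

This account rests on a few compounds, and the source may have more. Where it says the series, first, only, none or still open, it means among the compounds named here.

Compound 1 `CCOC(=O)C(CS)NC(=O)c1cc(C(C)(C)C)c(O)c(C(C)(C)C)c1` carries a hindered phenol amide; in a functional assay, with a stated time of 30 min, tested at 100 uM (a lower number here means a weaker effect, a higher number a stronger effect of the compound at the concentration tested), compound 1 gives 46%. Compound 2 `CCOC(=O)C(CS)NC(=O)/C=C/c1ccccc1` is the cinnamamide analogue, and in this assay compound 2 gives 42%. The difference between the two cores is not broken down here; the two values lie within the scatter of each other. Compound 3 `O=C(/C=C/c1ccccc1)NCCS` removes the ester from compound 2, the change being (hydrogen in place of ethoxycarbonyl on a saturated chain carbon bound to an amide-type nitrogen and a saturated chain carbon), and in this assay compound 3 gives 59%, a step of a number 17 percentage points higher from compound 2 to compound 3 (beyond the scatter).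

Compound 4 `CC(C)(C)c1cc(C(=O)NCCS)cc(C(C)(C)C)c1O` is the unmeasured counterpart of compound 1 with the same change, (hydrogen in place of ethoxycarbonyl on a saturated chain carbon bound to an amide-type nitrogen and a saturated chain carbon); the place is the same in both pairs. Going by the values given here, only one pair shows the change in this assay, so the expectation rests on it alone. Because compound 2 moved to compound 3 by a number 17 percentage points higher from compound 2 to compound 3 (beyond the scatter), a step of similar size is expected for compound 1 to compound 4, a number 16 percentage points higher from compound 1 to compound 4 (beyond the scatter). Compound 4 is therefore estimated at 62% in this assay, with a plausible range from 48% to 76%.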

Compound 4, a percentage reported as activity, at one concentration (the size of the read-out at that concentration, not a potency): 45%
Beside the measured number, compound 4's estimate is 17 percentage points above it; measured number outside the range, below it.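

In this assay, hydrogen in place of ethoxycarbonyl on the core of compound 1 gives a number 1 percentage points lower from compound 1 to compound 4 (within the scatter), so the rise seen on the core of compound 2 does not reappear here. The same change therefore gives different results on the two cores: the same change on two cores in this assay, a number 17 percentage points higher (beyond the scatter) from compound 2 to compound 3 and a number 1 percentage points lower (within the scatter) from compound 1 to compound 4, 18 percentage points apart, beyond the scatter of two such steps

In this series, a step read on one core is thus no reliable guide to the step on the other, although these two pairs show neither which part of the cores accounts for the gap nor how the change would behave on any further core.

From the compounds shown here alone, it remains open whether a carboxylic acid in place of ethoxycarbonyl would also give core-dependent steps, and whether a longer chain in place of 2-sulfanylethyl would do the same. The compounds shown also leave open what a hydroxyl group or an amine in place of the thiol would do on either core.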